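The source may hold more compounds than are shown below. What is called first, only, known or untested is meant among the compounds shown, and "the series" means these compounds.

In a physicochemical assay for solubility, read by HPLC, in phosphate buffer, measured as kinetic solubility, at pH 7.4 (a higher number here means a more soluble compound, a lower number a less soluble compound), compound 1 (`CCCC(=O)c1cc(-c2ccc(S(N)(=O)=O)cc2)n(-c2ccc(Cl)cc2)n1`) gives 25800 nM and compound 2 (`NS(=O)(=O)c1ccc(-c2cc(C(=O)C3CCC3)nn2-c2ccc(Cl)cc2)cc1`) gives 17200 nM so that the two lie within the scatter of each other. Compound 3 (`NS(=O)(=O)c1ccc(-c2cc(C(=O)C3CCCC3)nn2-c2ccc(Cl)cc2)cc1`) departs from compound 2 by one change, cyclopentyl in place of cyclobutyl on a carbonyl carbon with cyclopentyl in place of cyclobutyl on a carbonyl carbon. Among the compounds with values here, the one measured step that bears on it is a 1.5-fold lower number from compound 1 to compound 2 (0.18 log units; within the scatter) with cyclobutyl in place of propyl at that place. No step beyond the scatter is therefore expected in this assay (estimated as a 1.4-fold lower number from compound 2 to compound 3 (0.16 log units; within the scatter)). Compound 3 is expected at 12000 nM (estimated range 5000 nM to 24000 nM).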

Compound 3, solubility: 4600 nM
For compound 3 the middle estimate is 2.6-fold (0.42 log units) above the measured one, outside the stated range (below it).
By their numbers in this assay, from the lowest: compound 3; then compounds 2 and 1 (each within the scatter of the next).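

In this assay, the place on the carbonyl carbon, where the earlier change stayed within the scatter, now shows a step beyond it: cyclopentyl in place of cyclobutyl gives a 3.7-fold lower number from compound 2 to compound 3 (0.57 log units; beyond the scatter) in this series. Cyclopentyl in place of propyl gives a 5.6-fold lower number from compound 1 to compound 3 (0.75 log units; beyond the scatter) at the same place, so compound 3 stands apart from both compound 1 and compound 2. Nothing at hand accounts for this step.
On these data alone, whether a cyclohexyl ring would give a still lower number remains open. So does how an amine on the cyclopentyl ring would read.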